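Ester group swap: sec-butyl to phenyl

A few compounds are considered here, and "the series" means these few. Any claim that something is new, unique, unknown or untested is made for them only; others in the source may bear on it.

Values in an ADME assay on HeLa cells (Homo sapiens) for cytotoxicity, read by MTT assay, with a stated time of 2 days (a lower number here means that less compound is tolerated, a higher number that more compound is tolerated), so far:
- compound 1 `CCOC(=O)c1ccc2ccc(Oc3ccnc(C(=O)NC)c3)cc2c1` gives 13200 nM as its value
- compound 2 `CCC(C)OC(=O)c1ccc2ccc(Oc3ccnc(C(=O)NC)c3)cc2c1` gives 9000 nM as its value
- compound 3 `CNC(=O)c1cc(Oc2ccc3ccc(C(=O)Oc4ccccc4)cc3c2)ccn1` has no value yet

Set against compound 1, compound 2 at 9000 nM stands within the scatter, so the two cannot be ranked. The next change puts phenyl in place of sec-butyl on an oxygen next to a carbonyl group. Among the compounds with values here, only one measured step bears on this. It is a 1.5-fold lower number from compound 1 to compound 2 (0.17 log units; within the scatter) and it also alters the group on that oxygen, but it brings in no aromatic ring. The data therefore give no direction for phenyl, and a wide range is warranted. The expected size is a 1.1-fold lower number from compound 2 to compound 3 (0.05 log units; within the scatter) and nothing beyond the scatter is anticipated. Compound 3 is estimated at 8000 nM with an expected range of 3000 nM to 20000 nM in this assay for now.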

Compound 3, half-maximal cytotoxic concentration: > 100000 nM
Compound 3 ended at the assay's limit (the forecaster's own chance of this, stated with the estimate: 5%); at least 12-fold (1.09 log units) between middle value and limit.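

In this assay compound 3 gives > 100000 nM as a limit of the assay and not a number: the limit of > 100000 nM in this assay, at which 1 of the 3 values shown sits.

The group on an oxygen next to a carbonyl group can clearly move this read-out, which the ethyl and sec-butyl pair, standing within the scatter of each other, did not show. Phenyl gives a step beyond the scatter against both saturated chains, with sec-butyl leaving (an at least 11-fold higher number from compound 2 to compound 3 (1.04 log units; beyond the scatter)) and with ethyl leaving (an at least 7.5-fold higher number from compound 1 to compound 3 (0.87 log units; beyond the scatter)). Compound 3 is thus set apart from both chain esters, with the full size of each step unknown.

On these data alone, whether the shift belongs to the aromatic ring itself remains open, as only unsubstituted phenyl stands here, and a benzyl group or a methoxyphenyl group could separate these readings. A carboxylic acid or an amide in place of the ester would show whether the ester link matters at all.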